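The source may report more compounds than this note shows. Statements on the series, on what has been measured and on what is new or still open speak of the compounds shown alone.

Measured so far in a functional assay on HCT-8 cells (Homo sapiens) for cytotoxicity, read by MTT assay, with a stated time of 24 h; a higher number here means a weaker inhibitor, a lower number a stronger inhibitor:
Compound 1 `CC[C@H](C)[C@@H](NC(=O)Cn1cc(C2=C(c3c[nH]c4ccccc34)C(=O)N(C)C2=O)c2ccccc21)C(=O)OC` gives > 100000 nM, a limit of the assay rather than a number.
Compound 2 `COC(=O)[C@H](NC(=O)Cn1cc(C2=C(c3c[nH]c4ccccc34)C(=O)N(C)C2=O)c2ccccc21)[C@@H](C)O` gives 23400 nM.

Among the measured compounds shown here, compound 2 therefore holds the only number in this assay; the other value is a limit (the limit of > 100000 nM in this assay, at which 1 of the 2 values shown sits). Compound 3 `COC(=O)[C@@H](C)NC(=O)Cn1cc(C2=C(c3c[nH]c4ccccc34)C(=O)N(C)C2=O)c2ccccc21` differs from compound 2 by methyl in place of 1-hydroxyethyl on a saturated chain carbon bound to an amide-type nitrogen and a carbonyl carbon. For the measured compounds named here, the one measured step, an at least 4.2-fold lower number from compound 1 to compound 2 (0.63 log units; beyond the scatter), moved to a lower number when hydroxy entered in place of ethyl; here the hydroxy leaves again, so a move back toward a higher number, with a real chance of reaching the limit, is expected. Compound 3 is estimated at 60000 nM (range 20000 nM to 150000 nM), an expected step of a 2.6-fold higher number from compound 2 to compound 3 (0.41 log units; beyond the scatter).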

Compound 3, half-maximal inhibitory concentration: 21400 nM
Compound 3: the middle estimate sits 2.8-fold (0.45 log units) above what was measured; measured number inside the range.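

In this assay, the hydroxy that seemed to matter in the earlier step is not required at this position: methyl in place of 1-hydroxyethyl gives a 1.1-fold lower number from compound 2 to compound 3 (0.04 log units; within the scatter). The sec-butyl group of compound 1 is what stands apart, as methyl in its place gives an at least 4.6-fold lower number from compound 1 to compound 3 (0.66 log units; beyond the scatter). That step rests on a limit and not on a number: the limit of > 100000 nM in this assay, at which 1 of the 3 values shown sits.

As far as these compounds go, it remains open how a side chain carrying an amine or a carboxylic acid would read at this position. Whether a chain of intermediate length, such as ethyl or propyl, already reaches the limit is also unresolved.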